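The source may hold more compounds than are shown below. What is called first, only, known or untested is meant among the compounds shown, and "the series" means these compounds.

The compounds here share one core and differ only in the aromatic group attached to the carbon with a double bond to nitrogen. Compound 1 `COc1ccc(OC)c(/C=N/NC(=O)Nc2ccc(Oc3ccnc(-c4nncn4CCN(C)C)c3)c(F)c2)c1` carries a 2,5-dimethoxyphenyl group there. In an ADME assay on WI-38 cells (Homo sapiens) for cytotoxicity, read by MTT assay, with a stated time of 72 h (a higher number here means a weaker inhibitor, a lower number a stronger inhibitor), compound 1 gives "not determined" (no result reported): no result was reported for it. The same is true of compound 3 `COc1cc(/C=N/NC(=O)Nc2ccc(Oc3ccnc(-c4nncn4CCN(C)C)c3)c(F)c2)cc(OC)c1OC`, which carries a trimethoxyphenyl group; in this assay compound 3 gives "not determined" (no result reported), again with no reported result. Only compound 2 `COc1ccc(/C=N/NC(=O)Nc2ccc(Oc3ccnc(-c4nncn4CCN(C)C)c3)c(F)c2)c(OC)c1`, with a 2,4-dimethoxyphenyl group, has a number: in this assay compound 2 gives 6630 nM, a rather weak effect on these cells.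

Compound 4 `CN(C)CCn1cnnc1-c1cc(Oc2ccc(NC(=O)N/N=C/c3c(O)ccc4ccccc34)cc2F)ccn1` has not yet been measured. It differs from compound 1 in one place, (2-hydroxynaphthalen-1-yl in place of 2,5-dimethoxyphenyl on a carbon with a double bond to nitrogen).

Within the data shown here, no measured pair differing in one place is available, so the size of this step can only be guessed. Among the measured compounds shown here, with compound 1 itself lacking a number, the only anchor is compound 2, a close relative. My expectation is that compound 4 stays in a similar range, with no clear direction beyond the usual scatter of this assay, and that it may well come back as a limit rather than a number. For compound 4 in this assay I expect roughly 6000 nM, between 1500 nM and 25000 nM.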

Compound 4, half-maximal inhibitory concentration: 3250 nM
The estimate for compound 4 lay 1.8-fold (0.27 log units) above the measured number, and the stated range covers the measured number.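

In this assay, among these compounds, the change to 2-hydroxynaphthalen-1-yl in place of 2,4-dimethoxyphenyl gives a 2.0-fold lower number from compound 2 to compound 4 (0.31 log units; beyond the scatter) and so provides the first direct comparison at this place, on the carbon with a double bond to nitrogen. It shows that the aromatic group here can shift the effect on these cells beyond the usual scatter, although only modestly, and that a group with two six-membered aromatic rings and a hydroxyl still leaves the number in the same broad range as the dimethoxyphenyl compound. The single step cannot say which feature of the new group matters, and no measurement shown here accounts for the shift.

Steps involving compound 1 or compound 3 cannot be read, as neither has a number, so the 2,5-dimethoxyphenyl and trimethoxyphenyl groups remain outside the comparison. Going by these compounds, the second aromatic ring and the hydroxyl arrive together in compound 4, and it stays open which of them goes with the lower number, a question that a plain naphthalen-1-yl group or a phenyl ring bearing one hydroxyl could help to separate.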